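The source may report more compounds than this note shows. Statements on the series, on what has been measured and on what is new or still open speak of the compounds shown alone.

Among the compounds with values here, in a physicochemical assay for lipophilicity (on this read-out higher numbers stand for higher lipophilicity and lower numbers for lower lipophilicity), compound 1 `Cc1ccccc1C1C[C@@]2(ON1c1ccccc1)C(=O)O[C@@H]1[C@H]2CC[C@H](C)[C@]2(O)C=CC(=O)[C@@]12C` gives 3.64 and compound 2 `COc1cccc(C2C[C@@]3(ON2c2ccccc2)C(=O)O[C@@H]2[C@H]3CC[C@H](C)[C@]3(O)C=CC(=O)[C@@]23C)c1` gives 3.25, the lower of the two numbers so far. These compounds share one core and differ in a single place, and the measured step is a number 0.39 log units lower from compound 1 to compound 2 (beyond the scatter). Compound 3 `C[C@H]1CC[C@@H]2[C@@H](OC(=O)[C@]23CC(c2ccc([N+](=O)[O-])cc2)N(c2ccccc2)O3)[C@]2(C)C(=O)C=C[C@@]12O` keeps the same core and changes that same place: 4-nitrophenyl in place of 3-methoxyphenyl on a saturated ring carbon. Here 4-nitrophenyl stands in place of 3-methoxyphenyl on a saturated ring carbon, next to the ring nitrogen.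

Within the data shown here, only one measured step bears on this change, the modest one at the same carbon between compound 1 and compound 2. It involves a different pair of groups, so it offers a rough scale but no direct guide to direction. Among the measured compounds shown here, no measured compound here carries 4-nitrophenyl. A small change is therefore expected, probably within the scatter, with a tentative lean towards a lower number. The expected change is a number 0.10 log units lower from compound 2 to compound 3 (within the scatter). For compound 3 the estimated value is 3.15, with an expected range from 2.75 to 3.55.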

Compound 3, partition coefficient: 3.15
The estimate for compound 3 equals the measured number at the digits printed, and the stated range covers the measured number.
By their numbers in this assay, from the lowest: compounds 3 and 2 (each within the scatter of the next); then compound 1.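

In this assay the step is a number 0.10 log units lower from compound 2 to compound 3 (within the scatter) and so gives no sign of a difference at this saturated ring carbon, even though 3-methoxyphenyl and 4-nitrophenyl differ in their atoms and in their counts of hydrogen-bond acceptors. The second new step is a number 0.49 log units lower from compound 1 to compound 3 (beyond the scatter) and stands beyond the scatter, so compound 1, with 2-methylphenyl, now sits apart from both compound 2 and compound 3, which cannot be told apart on this read-out. Within these three compounds the separation therefore lies between 2-methylphenyl and the other two groups, though nothing measured here gives a reason for it or for the closeness of compound 2 and compound 3.

As far as these compounds go, all three compounds carry a substituted phenyl group at this carbon, so it remains open how far the number would move with a group of another kind there, such as an amine, a carboxylic acid or a longer chain. From the compounds shown here alone, it is also open whether 3-nitrophenyl, 4-methoxyphenyl or unsubstituted phenyl would stay with compound 2 and compound 3 or move towards compound 1.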